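A few compounds are considered here, and "the series" means these few. Any claim that something is new, unique, unknown or untested is made for them only; others in the source may bear on it.

Of the compounds shown here, three have been tested so far in a functional assay on ECa-109 cells (Homo sapiens) for cytotoxicity, read by MTT assay, with a stated time of 48 h (on this read-out higher numbers stand for weaker inhibition and lower numbers for stronger inhibition), and only one gives a real number. Compound 1 (`COc1cc(-n2c(-c3ccc(O)cc3)c[nH]c2=O)cc(OC)c1OC`) gives > 50000 nM as a limit of the assay and not as a number. Compound 2 (`COc1ccc(-c2cn(C(=O)Nc3cc(OC)c(OC)c(OC)c3)c(=O)n2-c2cc(OC)c(OC)c(OC)c2)cc1`) gives > 50000 nM as a limit too. For the measured compounds named here, compound 3 (`COc1cc(-n2c(-c3ccc(Br)cc3)cn(C(C)=O)c2=O)cc(OC)c1OC`) gives 3800 nM and so stands alone as the only measured number in the set.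

Compound 4 (`COc1ccc(-c2cn(C(C)=O)c(=O)n2-c2cc(OC)c(OC)c(OC)c2)cc1`) is compound 3 with a single change: methoxy in place of bromo on an aromatic carbon turns the 4-bromophenyl into a 4-methoxyphenyl. Going by the values given here, no pair of tested compounds isolates this swap. Compound 2 also carries a 4-methoxyphenyl, but it differs from compound 4 elsewhere as well, so it offers no clean comparison.

With only compound 3 at 3800 nM as an anchor, no shift beyond the usual scatter of this assay is expected, and any firm direction would be a guess. The expected change is a 1.3-fold lower number from compound 3 to compound 4 (0.10 log units; within the scatter) and the uncertainty around it is wide. For compound 4 the estimated value is 3000 nM with an expected range from 600 nM to 15000 nM in this comparison.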

Compound 4, half-maximal inhibitory concentration: > 50000 nM
Compound 4: only a limit was reported; the forecaster's own chance of this, stated with the estimate: 10%; middle value at least 16-fold (1.22 log units) away from the limit.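

In this assay, for the compounds shown here, the first comparison in the set where only one place changes gives an at least 13-fold higher number from compound 3 to compound 4 (1.11 log units; beyond the scatter). Going by these compounds alone, this shows that the aromatic carbon carrying the bromo group is not indifferent to its substituent: with the rest of the molecule held fixed, methoxy in place of bromo takes the compound from a measured value to no measured value at all, and the earlier compounds could not show this because none of them formed such a pair. The true size of the step stays unknown, and the printed figure is only a floor, because compound 4 ends at a limit of the assay and not at a number: the limit of > 50000 nM in this assay, at which 3 of the 4 values shown sit.

Within the data shown here, with only two groups compared on this carbon, the result cannot say whether bromo is specifically favourable or methoxy is specifically unfavourable, and a plain hydrogen, a chloro, a methyl or an amine at the same place would help to tell these two readings apart. Going by these compounds, it also remains open whether the same swap would have the same effect on a different core, and whether it would hold in another cell line.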